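Compound 2 to compound 3: hydroxy to methoxy

This account rests on a few compounds, and the source may have more. Where it says the series, first, only, none or still open, it means among the compounds named here.

Compound 1 (`COc1ccc(NC(=O)Nc2cc(C)nc3ccccc23)cc1Cl`): > 25000 nM (a limit)
Compound 2 (`Cc1cc(NC(=O)Nc2ccc(O)cc2)c2ccccc2n1`): > 25000 nM (a limit)

Both entries come from an ADME assay on Raji cells (Homo sapiens) for cytotoxicity, with a stated time of 72 h (on this read-out higher numbers stand for an effect only at larger amounts of compound and lower numbers for an effect already at smaller amounts), and neither is an exact number. Compound 1 gives > 25000 nM there, which is a limit. Compound 2 gives > 25000 nM in the same test, which is also a limit. So the data place compound 2 at the limit and give no exact value for it. The same holds across the small set (the limit of > 25000 nM in this assay, at which 2 of the 2 values shown sit).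

Compound 3 (`COc1ccc(NC(=O)Nc2cc(C)nc3ccccc23)cc1`) differs from compound 2 in one place (methyl in place of hydrogen on an oxygen on an aromatic ring). It has methyl in place of hydrogen on an oxygen on an aromatic ring, so hydroxy becomes methoxy.

Going by the values given here, no measured pair shows what this change does in this assay, so the expectation rests only on the two limits seen so far. No step beyond the usual scatter is expected (a number no higher from compound 2 to compound 3 (the limit leaves the size open)), and a further limit is the likeliest report. For compound 3 the estimated value is 25000 nM, with an expected range from 12000 nM to 50000 nM.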

Compound 3, half-maximal effective concentration: > 25000 nM
Compound 3 ended at the assay's limit; the forecaster's own chance of this, stated with the estimate: 85%; the middle value sits exactly at the limit.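

Compound 3 gives a limit, so no step can be read from compound 2 to compound 3 or from compound 1 to compound 3, and all three sit at the same limit: the limit of > 25000 nM in this assay, at which 3 of the 3 values shown sit.

The compounds shown leave open whether hydroxy to methoxy, or hydrogen in place of chloro, changes the read-out, and at what amount compound 1, compound 2 or compound 3 would show an effect.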